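This account rests on a few compounds, and the source may have more. Where it says the series, first, only, none or still open, it means among the compounds named here.

Measured in a functional assay on HCT-116 cells (Homo sapiens) for inhibition, read by MTT assay, with a stated time of 48 h; a higher number here means a weaker inhibitor, a lower number a stronger inhibitor:
compound 1 `CCC/C=C/C(=O)N(Cc1ccc(OC)c(O)c1)c1cc(OC)c(OC)c(OC)c1` gives 95 nM
compound 2 `C/C=C/C(=O)N(Cc1ccc(OC)c([N+](=O)[O-])c1)c1cc(OC)c(OC)c(OC)c1` gives 670 nM
compound 3 `COc1ccc(CN(C(=O)CBr)c2cc(OC)c(OC)c(OC)c2)cc1O` gives 68 nM

Compound 3 stands at the lowest number of the three; compound 1 sits within the scatter of it, compound 2 lies beyond it. Compound 4 `C/C=C/C(=O)N(Cc1ccc(OC)c(O)c1)c1cc(OC)c(OC)c(OC)c1` is not yet measured in this assay. It differs from compound 3 by prop-1-en-1-yl in place of bromomethyl on a carbonyl carbon. Among the compounds with values here, the one measured step that bears on this change is a 1.4-fold lower number from compound 1 to compound 3 (0.15 log units; within the scatter), in which pent-1-en-1-yl on the same carbonyl carbon was exchanged for bromomethyl without leaving the scatter. Read in reverse, it argues for at most a small drift back toward compound 1. Compound 2 differs in another place and is not a guide here. Compound 4 is expected to lie close to compound 3. The step of a 1.6-fold higher number from compound 3 to compound 4 (0.21 log units; within the scatter) is expected to stay within the scatter. The estimate for compound 4 is 110 nM, with a range of 45 nM to 300 nM.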

Compound 4, half-maximal inhibitory concentration: 55 nM
Compound 4: middle estimate off by 2.0-fold (0.30 log units), on the high side; measured number inside the range.
By their numbers in this assay, from the lowest: compounds 4, 3 and 1 (each within the scatter of the next); then compound 2.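

Working notes: on the carbonyl carbon, prop-1-en-1-yl and bromomethyl cannot be told apart (a 1.2-fold lower number from compound 3 to compound 4 (0.09 log units; within the scatter)), and hydrogen in place of ethyl on the chain also stays within the scatter (a 1.7-fold lower number from compound 1 to compound 4 (0.24 log units; within the scatter)). Within the data shown here, the aromatic carbon gives the first clean reading of a large effect, with hydroxy in place of nitro (a 12-fold lower number from compound 2 to compound 4 (1.09 log units; beyond the scatter)), though from this one pair only. No measurement on hand accounts for either outcome.

Open, as far as these compounds go, is whether an amine on that aromatic carbon would sit with hydroxy or with nitro. Also open is whether a saturated propyl group on the carbonyl carbon would stay within the scatter of these compounds.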